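This account rests on a few compounds, and the source may have more. Where it says the series, first, only, none or still open, it means among the compounds named here.

Working notes on the series. In a functional assay on cells (Cancer cell lines, Homo sapiens) for cytotoxicity, with a stated time of 48 h (a lower number here means a stronger inhibitor of growth, a higher number a weaker inhibitor of growth), compound 1 (`COc1cc(/C=C2/C(=O)N(C)c3ccc(O)cc32)cc(OC)c1OC`) gives 26300 nM, compound 2 (`COc1ccc2c(c1)/C(=C\c1cc(OC)c(OC)c(OC)c1)C(=O)N2C`) gives 28200 nM and compound 3 (`COc1cc(/C=C2\C(=O)N(C)c3ccc(Cl)cc32)cc(OC)c1OC`) gives 36300 nM. Compound 2 stands within the scatter of both other compounds, so the three cannot be ranked. The next compound is compound 4 (`COc1ccc(CN2C(=O)/C(=C/c3cc(OC)c(OC)c(OC)c3)c3cc(OC)ccc32)cc1`), which differs from compound 2 in one place: 4-methoxyphenyl in place of hydrogen on a saturated chain carbon bound to an amide-type nitrogen in a ring. Read one bond further out, this is methyl to 4-methoxybenzyl. For the measured compounds named here, the only measured step, a 1.1-fold higher number from compound 1 to compound 2 (0.03 log units; within the scatter), is methyl in place of hydrogen on an oxygen on an aromatic ring. That is a different change at a different place, so it gives no direct guide here. Going by the values given here, no measured compound carries 4-methoxyphenyl, and the expectation is therefore loose: a modest shift towards a lower number in this assay, possibly no larger than the scatter. The expected change is a 2.0-fold lower number from compound 2 to compound 4 (0.30 log units; within the scatter). For compound 4 the estimated value is 14000 nM, with an expected range of 3500 nM to 45000 nM.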

Compound 4, concentration for total growth inhibition: 8900 nM
Estimate against measurement, compound 4: 1.6-fold (0.20 log units) above, within the range that was stated.
By their numbers in this assay, from the lowest: compound 4; then compounds 1, 2 and 3 (each within the scatter of the next).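

In this assay, for the compounds shown here, changing methyl to 4-methoxybenzyl on the amide-type nitrogen in a ring gives a 3.2-fold lower number from compound 2 to compound 4 (0.50 log units; beyond the scatter) and is the first step that lies beyond the scatter. The only earlier step was a change on an oxygen on an aromatic ring and lay within the scatter, so this position is the first place shown where one change moves the number, even with 4-methoxyphenyl adding a whole aromatic ring. No available evidence bears on the reason for this shift. Still open, going by these compounds, is whether the shift needs the methoxy of the new group, which a plain benzyl at this place would test. A longer chain without an aromatic ring, or a benzyl carrying an amine or a carboxylic acid, would show how far the position accepts other groups.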